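The compounds below may be only part of what the source reports. "The series", "measured", "known", "first", "only" and "open" are said of these compounds alone.

In a functional assay on HT-29 cells (Homo sapiens) for antiproliferative activity, read by sulforhodamine B assay, with a stated time of 72 h (on this read-out higher numbers stand for weaker inhibition and lower numbers for stronger inhibition), measured so far:
- compound 1 `CCCCCCCCc1ccc(CCC(CO)(CO)NC(C)=O)c2ccccc12` gives 36500 nM
- compound 2 `CCCCCCCCc1ccc(CCC(CO)(CO)NC(=O)c2ccccc2)c2ccccc12` gives 23000 nM
- compound 3 `CC(=O)NC(CO)(CO)CCc1ccc(O)c2ccccc12` gives > 80000 nM (a limit)

Compound 3 has no number, only the limit > 80000 nM. Compound 4 `COc1ccc(CCC(CO)(CO)NC(C)=O)c2ccccc12` differs from compound 3 by methyl in place of hydrogen on an oxygen on an aromatic ring, hydroxy to methoxy. The closest measured step is an at least 2.1-fold higher number from compound 1 to compound 3 (0.34 log units; beyond the scatter), which also changes the group on an aromatic carbon but is open-ended, with the limit of > 80000 nM in this assay, at which 1 of the 3 values shown sits. The step of a 1.6-fold lower number from compound 1 to compound 2 (0.20 log units; within the scatter) concerns the carbonyl carbon and bears little on this change. Compound 4 is therefore expected to remain weak in this assay, with only a small move towards a lower number, possibly none beyond the scatter. The estimated step is an at least 1.1-fold lower number from compound 3 to compound 4 (0.05 log units; that floor lies within the scatter). The estimate for compound 4 is 70000 nM, with an expected range from 35000 nM to 100000 nM.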

Compound 4, half-maximal inhibitory concentration: > 80000 nM
Compound 4: a limit, no number; the forecaster's own chance of this, stated with the estimate: 55%; middle value at least 1.1-fold (0.05 log units) from the limit.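

In this assay compound 4 gives > 80000 nM, which is a limit and not a number. Methyl in place of hydrogen on the oxygen therefore yields no readable step from compound 3 to compound 4, and the series gains a second value at a limit: the limit of > 80000 nM in this assay, at which 2 of the 4 values shown sit. Methoxy in place of octyl on the aromatic carbon gives an at least 2.1-fold higher number from compound 1 to compound 4 (0.34 log units; beyond the scatter), so the loss seen with hydroxy also appears with methoxy.

Still open, from the compounds shown here alone, is whether a butyl chain or an amine at that aromatic carbon would give a readable value.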